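The compounds below may be only part of what the source reports. "The series", "measured", "known", "first", "only" and "open" are said of these compounds alone.

In a functional assay on SNB-75 cells (Homo sapiens) for antiproliferative activity (on this read-out lower numbers stand for stronger inhibition of growth and higher numbers for weaker inhibition of growth), compound 1 `COc1cc(-n2cc(-c3ccc(Cl)cc3)[nH]c2=O)cc(OC)c1OC` gives 25100 nM. Compound 3 `COc1ccc(-c2cn(-c3ccc(Cl)cc3)c(=S)[nH]2)cc1OC` gives 15800 nM, and these two values lie within the usual scatter of each other, so compound 1 stands level with compound 3. Compound 2 `COc1cc(-c2cn(-c3ccc(Cl)cc3)c(=O)[nH]2)cc(OC)c1OC` gives only a limit of the assay, > 100000 nM. Compound 4 `COc1cc(-n2cc(-c3ccccc3)[nH]c2=O)cc(OC)c1OC` has not yet been measured. It differs from compound 1 in one place: hydrogen in place of chloro on an aromatic carbon, with hydrogen in place of chloro on an aromatic carbon. Among the measured compounds shown here, no measured pair of compounds shows this change, so any prediction is uncertain. The estimated step of a 1.3-fold higher number from compound 1 to compound 4 (0.11 log units; within the scatter) is expected to be small, staying within the scatter. For compound 4 the estimate is 32000 nM, with the result expected between 12000 nM and 90000 nM.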

Compound 4, concentration for 50% growth inhibition: 12600 nM
Beside the measured number, compound 4's estimate is 2.5-fold (0.40 log units) above it; the measured number falls inside the stated range.
By their numbers in this assay, from the lowest: compounds 4, 3 and 1 (each within the scatter of the next). At a limit, above all of these: compound 2.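

Going from 4-chlorophenyl to phenyl gives a 2.0-fold lower number from compound 1 to compound 4 (0.30 log units; within the scatter) in this assay. Among the compounds shown here, this is the first direct reading of a change at this position, para to a large group, and it shows that the growth-inhibiting activity of this series does not depend on the chloro, since compound 4 keeps it without that atom. Nothing measured here offers a reason for this result. Still open, on these data alone, is how an amine or a carboxylic acid at this position would read. As far as these compounds go, whether swapping chloro for hydrogen gives a similar step on other cores also remains unknown.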